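Acetamido for Phenoxy on a Shared Thiourea Core

A few compounds are considered here, and "the series" means these few. Any claim that something is new, unique, unknown or untested is made for them only; others in the source may bear on it.

Among the measured compounds shown here, compound 2 `S=C(Nc1ccc(Oc2ccccc2)cc1)Nc1ccc2[nH]ccc2c1` gives 73.1% in an ADME assay on isolated protein for inhibition of peroxidase (Raphanus sativus), read by fluorescence and Amplex Red, tested at 5 uM (a higher number here means a weaker effect of the compound at the concentration tested, a lower number a stronger effect), the lowest of the two numbers measured so far, while compound 1 `OCc1ccc(NC(=S)Nc2ccc3[nH]ccc3c2)cc1` gives 88.3%. For the measured compounds named here, the only measured step, a number 15.2 percentage points lower from compound 1 to compound 2 (beyond the scatter), exchanged a group with no ring for one with a ring. Compound 3 `CC(=O)Nc1ccc(NC(=S)Nc2ccc3[nH]ccc3c2)cc1` differs from compound 2 by acetamido in place of phenoxy on an aromatic carbon. Because the step of a number 15.2 percentage points lower from compound 1 to compound 2 (beyond the scatter) exchanged a group with no ring for one with a ring, and acetamido like hydroxymethyl has no ring, a move of similar size back upward is expected: a number 11.9 percentage points higher from compound 2 to compound 3 (beyond the scatter). Compound 3 is therefore estimated at 85%, with a range from 70% to 98%.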

Compound 3, a percentage reported as activity, at one concentration (the size of the read-out at that concentration, not a potency): 68.1%
Compound 3: middle estimate off by 16.9 percentage points, on the high side; the measured number lies below the stated range.
By their numbers in this assay, from the lowest: compounds 3 and 2 (each within the scatter of the next); then compound 1.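

In this assay, a ring on this aromatic carbon turns out not to be needed to reach the number given by phenoxy, as acetamido, which has no ring, stays within the scatter of it (a number 5 percentage points lower from compound 2 to compound 3 (within the scatter)). Having no ring does not by itself give a number like that of compound 1, as the step to a different ring-free group shows (a number 20.2 percentage points lower from compound 1 to compound 3 (beyond the scatter)). Nothing measured here explains either step. From the compounds shown here alone, it remains open whether an amine or a carboxylic acid at this place would fall with compound 1 or with compound 2 and compound 3.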